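From Isopropyl to Bromo on the Phenyl Arm

A few compounds are considered here, and "the series" means these few. Any claim that something is new, unique, unknown or untested is made for them only; others in the source may bear on it.

Of the compounds shown here, three built on one shared core have been measured in a functional assay on B16-F10 cells (Mus musculus) for inhibition, read by MTT assay, with a stated time of 72 h; on this read-out higher numbers stand for weaker inhibition and lower numbers for stronger inhibition. Compound 1 `N#Cc1c(Nc2ccccc2Cl)nc(SCc2cn(Cc3ccccc3Cl)nn2)nc1-c1ccccc1` gives 8350 nM. Compound 2 `Cc1ccc(Nc2nc(SCc3cn(Cc4ccccc4Cl)nn3)nc(-c3ccc(C(C)C)cc3)c2C#N)cc1` gives 3530 nM, the second highest of the three numbers. Compound 3 `COc1ccc(Nc2nc(SCc3cn(Cc4ccccc4Cl)nn3)nc(-c3ccc(C(C)C)cc3)c2C#N)cc1` gives 2690 nM. Going by the values given here, the only single-place step measured so far, a 1.3-fold lower number from compound 2 to compound 3 (0.12 log units; within the scatter), lies within the scatter, so compound 2 and compound 3 cannot be told apart. Compound 1 lies furthest from compound 2, with a higher number beyond the scatter, but these two compounds differ in more than one place, so no single step can be read from that gap.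

Compound 4 `Cc1ccc(Nc2nc(SCc3cn(Cc4ccccc4Cl)nn3)nc(-c3ccc(Br)cc3)c2C#N)cc1` has not yet been measured. It differs from compound 2 in one place: bromo in place of isopropyl on an aromatic carbon. Among the compounds with values here, none of the measured steps touches this group; the one single-change step available concerns another part of the molecule. There is thus no direct guide, and no step beyond the scatter is expected. The step of a 1.1-fold higher number from compound 2 to compound 4 (0.05 log units; within the scatter) is expected to be small. Compound 4 is expected to give about 4000 nM in this assay, within a range from 1500 nM to 10000 nM.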

Compound 4, half-maximal inhibitory concentration: 2870 nM
Compound 4: middle estimate off by 1.4-fold (0.14 log units), on the high side; the measured number falls inside the stated range.
By their numbers in this assay, from the lowest: compounds 3, 4 and 2 (each within the scatter of the next); then compound 1.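

Going by these compounds alone, this is the first step that touches the phenyl arm: in this assay, going from 4-isopropylphenyl to 4-bromophenyl gives a 1.2-fold lower number from compound 2 to compound 4 (0.09 log units; within the scatter). Compound 2 and compound 4 therefore cannot be told apart, so at this place, on an aromatic carbon para to a large group, isopropyl with its 3 heavy atoms and bromo with its 1 heavy atom read alike, at least with the rest of compound 2 held fixed. No measurement shown here offers an explanation for this likeness.

Both groups have 0 hydrogen-bond donors, 0 hydrogen-bond acceptors and no net charge, so the compounds shown leave open whether an amine or a carboxylic acid at this place would also leave the number within the scatter of compound 2. They also leave open what a longer chain such as hexyl would do here, and whether the swap from isopropyl to bromo would read the same with the methoxy group of compound 3 in place of the methyl group of compound 2.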